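This account rests on a few compounds, and the source may have more. Where it says the series, first, only, none or still open, it means among the compounds named here.

In an ADME assay on J774.A1 cells (Mus musculus) for cytotoxicity, read by MTT assay, with a stated time of 48 h (a lower number here means that less compound is tolerated, a higher number that more compound is tolerated), compound 1 `COc1ccc(CNC(=O)c2c([N+](=O)[O-])noc2-c2ccc(Cl)cc2)cc1` gives 89500 nM and compound 2 `COC(=O)c1c(NCc2ccccc2)noc1-c1ccc([N+](=O)[O-])cc1` gives 85400 nM as its reading. Compound 3 `COC(=O)c1c(NCCNc2ccnc3cc(Cl)ccc23)noc1-c1ccc([N+](=O)[O-])cc1` gives 3790 nM as the lowest of the three numbers, well beyond the usual scatter from both others. Compound 4 `COC(=O)c1c(NCCNc2ccnc3cc(Cl)ccc23)noc1-c1ccc(Cl)cc1Cl` awaits measurement. It carries 2,4-dichlorophenyl in place of 4-nitrophenyl on an aromatic carbon, and the counted change is 2,4-dichlorophenyl in place of 4-nitrophenyl on an aromatic carbon in full. Within the data shown here, no measured pair shows this swap alone. Compound 4 shares with compound 3 the large group absent from compound 1 and compound 2, which makes compound 3 at 3790 nM the closest guide, and no step beyond the scatter is expected. The expected step of a 1.2-fold higher number from compound 3 to compound 4 (0.07 log units; within the scatter) is therefore small. For compound 4 the estimated value is 4500 nM with an expected range from 1800 nM to 11000 nM in all.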

Compound 4, half-maximal cytotoxic concentration: 3450 nM
The estimate for compound 4 lay 1.3-fold (0.12 log units) above the measured number; low and high end bracket the measured number.
By their numbers in this assay, from the lowest: compounds 4 and 3 (each within the scatter of the next); then compounds 2 and 1 (each within the scatter of the next).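

In this assay, among these compounds, putting 2,4-dichlorophenyl in place of 4-nitrophenyl on the aromatic carbon next to the ring oxygen gives a 1.1-fold lower number from compound 3 to compound 4 (0.04 log units; within the scatter) as the first direct reading of this swap. At this position, then, the two aryl groups give cell tolerance readings that cannot be told apart, even though only 4-nitrophenyl carries oxygen atoms and only 2,4-dichlorophenyl carries chlorine. No measurement at hand offers an explanation for this. Still open, from the compounds shown here alone, is how a phenyl ring bearing an amine or a carboxylic acid would read here. Whether the swap behaves alike without the large group shared by compound 3 and compound 4 is also unknown.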